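The source may hold more compounds than are shown below. What is called first, only, known or untested is meant among the compounds shown, and "the series" means these compounds.

Measured so far:
- compound 1 `Cn1c(=O)c(S(=O)(=O)c2ccc(F)cc2F)cc2cnc(Nc3ccc4c(c3)CC(=O)N4)nc21`: 100000 nM
- compound 2 `Cn1c(=O)c(S(=O)(=O)c2ccc(F)cc2F)cc2cnc(Nc3ccccn3)nc21`: 75000 nM

In a functional assay on DU-145 cells (Homo sapiens) for inhibition, read by trypan blue exclusion, with a stated time of 72 h (a lower number here means a stronger inhibitor, a higher number a weaker inhibitor), compound 2 gives 75000 nM and compound 1 gives 100000 nM. These two numbers lie within the scatter of each other, so neither compound can be ranked above the other.

The next compound, compound 3 `Cn1c(=O)c(S(=O)(=O)c2ccc(F)cc2F)cc2cnc(Nc3ccc4c(c3)C(=O)C(=O)N4)nc21`, keeps the shared core and changes one group: a group of 11 heavy atoms (8 carbon, 1 nitrogen, 2 oxygen; one five-membered non-aromatic ring with 1 hetero atom, one six-membered aromatic ring of carbon only) in place of a group of 6 heavy atoms (5 carbon, 1 nitrogen; one six-membered aromatic ring with 1 hetero atom), on a nitrogen on an aromatic ring. The incoming group has one five-membered non-aromatic ring with 1 hetero atom and one six-membered aromatic ring of carbon only. The group in compound 1 has the same two ring types in the same place.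

Within the data shown here, only one measured step bears on this change: a 1.3-fold lower number from compound 1 to compound 2 (0.12 log units; within the scatter). That exchange, between a pyridin-2-yl group and a two-ring group, did not move the number beyond the scatter. One step is a thin basis, and the data do not show what the two added double bonds outside aromatic rings will do.

The expected size of the change is a 1.1-fold lower number from compound 2 to compound 3 (0.03 log units; within the scatter), so no shift beyond the scatter is expected. Compound 3 is estimated at 70000 nM, with an expected range of 25000 nM to 150000 nM.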

Compound 3, half-maximal inhibitory concentration: 75000 nM
The estimate for compound 3 lay 1.1-fold (0.03 log units) below the measured number; low and high end bracket the measured number.
By their numbers in this assay, from the lowest: compounds 2, 3 and 1 (each within the scatter of the next).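

In this assay there is no change at the digits printed from compound 2 to compound 3 (within the scatter), so the pyridin-2-yl group and the larger two-ring group with its two double bonds outside aromatic rings cannot be told apart at this position. The two closely related two-ring groups cannot be told apart either, with a 1.3-fold lower number from compound 1 to compound 3 (0.12 log units; within the scatter); among these three compounds, then, neither the size of the group on this nitrogen nor the added double bond outside the aromatic rings is tied to a shift beyond the scatter. Nothing measured here explains why the three groups read alike.

From the compounds shown here alone, what stays open is whether any group on this nitrogen can move the number beyond the scatter, since all three compounds carry an aromatic ring there, and a phenyl ring bearing a carboxylic acid or an open chain ending in an amine might read differently. All three also share the same core, so they leave open whether a change elsewhere in the molecule would matter more than a change at this position.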